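This account rests on a few compounds, and the source may have more. Where it says the series, first, only, none or still open, it means among the compounds named here.

In a functional assay on L1210 cells (Mus musculus) for inhibition (a higher number here means a weaker inhibitor, a lower number a stronger inhibitor), three compounds have been measured, and only one of them gives a number. Compound 1 (`C#CCN(Cc1ccc2nc(-n3ccnc3)nc(O)c2c1)c1ccc(C(=O)NC(CCC(=O)O)C(=O)O)cc1`) reports only a limit, > 100000 nM. Compound 3 (`C#CCN(Cc1ccc2nc(Oc3ccccc3)nc(O)c2c1)c1ccc(C(=O)NC(CCC(=O)O)C(=O)O)cc1`) also reports only a limit, > 100000 nM. Compound 2 (`COc1nc(O)c2cc(CN(CCCO)c3ccc(C(=O)NC(CCC(=O)O)C(=O)O)cc3)ccc2n1`) gives a true reading of 80000 nM. Compound 3 therefore stands at the limit of > 100000 nM in this assay, at which 2 of the 3 values shown sit, and no number can be given for its potency.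

Compound 4 (`C#CCN(Cc1ccc2nc(SC)nc(O)c2c1)c1ccc(C(=O)NC(CCC(=O)O)C(=O)O)cc1`) keeps the rest of compound 3 and carries methylsulfanyl in place of phenoxy on an aromatic carbon, between two ring nitrogen atoms: methylsulfanyl in place of phenoxy on an aromatic carbon.

Among the measured compounds shown here, the only measured step that bears on this change is a step that the two limits leave unreadable from compound 1 to compound 3, and it offers no size to scale from. The expectation therefore leans on compound 2, whose 80000 nM shows that a reading can be obtained in this weak range. A move toward stronger inhibition is expected, but only a moderate one, and compound 4 may well report only a limit again. The expected step is an at least 2.5-fold lower number from compound 3 to compound 4 (0.39 log units; beyond the scatter). For compound 4 the estimated value is 40000 nM, with an expected range from 6000 nM to 100000 nM.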

Compound 4, half-maximal inhibitory concentration: 13000 nM
Beside the measured number, compound 4's estimate is 3.1-fold (0.49 log units) above it; low and high end bracket the measured number.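

In this assay, the aromatic carbon between two ring nitrogen atoms turns out to be a place where a change of group can move the reading. Methylsulfanyl in place of phenoxy gives an at least 7.6-fold lower number from compound 3 to compound 4 (0.88 log units; beyond the scatter), and methylsulfanyl in place of 1H-imidazol-1-yl gives an at least 7.6-fold lower number from compound 1 to compound 4 (0.88 log units; beyond the scatter). The earlier step between the phenoxy and 1H-imidazol-1-yl compounds cannot be read, so neither of them could show this, and the two new steps give only the smallest size the change can have because their starting points are limits and not numbers: the limit of > 100000 nM in this assay, at which 2 of the 4 values shown sit.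

The compounds shown leave open whether the sulfur atom or the loss of the six-membered aromatic ring of the phenoxy group goes with the change, since methylsulfanyl differs from phenoxy in both at once and compound 4 is the only compound with a number on this core. They also leave open how an ethylsulfanyl group, a longer chain on the sulfur or an amine at this carbon would read on the core of compound 4.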